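Dimethylamino Added to a Trifluoromethylphenyl Urea Inhibitor

This account rests on a few compounds, and the source may have more. Where it says the series, first, only, none or still open, it means among the compounds named here.

Measured compounds:
compound 1 `CC(C)c1cccc(C(C)C)c1NC(=O)NCC1(c2ccccc2C(F)(F)F)CCCC1` 18 nM
compound 2 `CC(C)c1cccc(C(C)C)c1NC(=O)NCC1(c2cccc(N(C)C)c2)CCCC1` 33 nM

Among the measured compounds shown here, in an assay on microsomes for inhibition of acyl-CoA:cholesterol acyltransferase (Oryctolagus cuniculus) (a higher number here means a weaker inhibitor, a lower number a stronger inhibitor), compound 1 gives 18 nM, and its only neighbour is compound 2, with a 1.8-fold higher number from compound 1 to compound 2 (0.26 log units; within the scatter). Compound 3 `CC(C)c1cccc(C(C)C)c1NC(=O)NCC1(c2ccc(N(C)C)cc2C(F)(F)F)CCCC1` has not been measured. It differs from compound 1 by dimethylamino in place of hydrogen on an aromatic carbon. The single measured step that bears on this change, a 1.8-fold higher number from compound 1 to compound 2 (0.26 log units; within the scatter), stayed within the scatter, and nothing else among these compounds points to a larger effect. Compound 3 is therefore expected to land close to compound 1, with a 1.4-fold higher number from compound 1 to compound 3 (0.14 log units; within the scatter) estimated. The estimate for compound 3 is 25 nM, in a range from 9 nM to 70 nM.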

Compound 3, half-maximal inhibitory concentration: 50 nM
For compound 3 the middle estimate is 2.0-fold (0.30 log units) below the measured one; the measured number falls inside the stated range.
By their numbers in this assay, from the lowest: compounds 1, 2 and 3 (each within the scatter of the next, the first and the last beyond it).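

In this assay, dimethylamino on this aromatic carbon, meta to a trifluoromethyl group and para to a large group, gives a 2.8-fold higher number from compound 1 to compound 3 (0.44 log units; beyond the scatter). This is a modest step, but unlike the only earlier one it lies beyond the scatter, so this change to compound 1 has a measurable cost at this position. No available measurement accounts for this step.

The compounds shown leave open whether this cost is specific to dimethylamino. They also leave open how a methoxy group, a fluorine atom or a primary amine on the same carbon would compare.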